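Halogenated phenyl on the ring nitrogen: outlook for compound 4

This account rests on a few compounds, and the source may have more. Where it says the series, first, only, none or still open, it means among the compounds named here.

In a functional assay on U-87MG ATCC cells for antiproliferative activity against U-87 MG (Homo sapiens), read by MTT assay, with a stated time of 72 h (a higher number here means a weaker inhibitor, a lower number a stronger inhibitor), compound 3 `Cn1ccc2c(Oc3ccc(NC(=O)c4cc5cccnc5n(-c5ccccc5)c4=O)cc3)ccnc21` gives 5030 nM, the highest number among the three measured compounds; compound 1 `O=C(Nc1ccc(Oc2ccnc3[nH]ccc23)cc1)c1cc2cccnc2n(-c2ccccc2)c1=O` gives 1580 nM and compound 2 `O=C(Nc1ccc(Oc2ccnc3[nH]ccc23)cc1)c1cc2cccnc2n(-c2ccc(Cl)cc2)c1=O` gives 3370 nM in this assay. Compound 4 `Cn1ccc2c(Oc3ccc(NC(=O)c4cc5cccnc5n(-c5ccc(F)c(Cl)c5)c4=O)cc3)ccnc21` differs from compound 3 by 3-chloro-4-fluorophenyl in place of phenyl on an aromatic nitrogen. For the measured compounds named here, two measured steps bear on this change: a 3.2-fold higher number from compound 1 to compound 3 (0.50 log units; beyond the scatter), which compound 3 already carries, and a 2.1-fold higher number from compound 1 to compound 2 (0.33 log units; beyond the scatter), the closest precedent for a halogen on this phenyl. Both steps were modest and in the same direction, so a further modest rise in this assay is expected for compound 4, about a 2.0-fold higher number from compound 3 to compound 4 (0.30 log units; within the scatter). Compound 4 is accordingly estimated at 10000 nM in this assay, with a range of 4000 nM to 25000 nM.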

Compound 4, half-maximal inhibitory concentration: 2350 nM
Compound 4: middle estimate off by 4.3-fold (0.63 log units), on the high side, and the stated range ends above it.
By their numbers in this assay, from the lowest: compounds 1, 4, 2 and 3 (each within the scatter of the next, the first and the last beyond it).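

In this assay, halogen on this phenyl does not push the number one way: 3-chloro-4-fluorophenyl in place of phenyl, with the methyl on the aromatic nitrogen, lowers it (a 2.1-fold lower number from compound 3 to compound 4 (0.33 log units; beyond the scatter)), whereas chloro in place of hydrogen, without that methyl, raises it (a 2.1-fold higher number from compound 1 to compound 2 (0.33 log units; beyond the scatter)). The two steps differ in halogen pattern and in that methyl, so neither can be singled out. Nothing available explains the opposite directions.

Open, as far as these compounds go, is how 3-chloro-4-fluorophenyl behaves without the methyl, and whether a lone fluoro or a dimethylamino group on this phenyl lowers the number.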